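The source may hold more compounds than are shown below. What is called first, only, known or untested is meant among the compounds shown, and "the series" means these compounds.

Measured in a functional assay on HT-29 cells (Homo sapiens) for cytotoxicity, read by MTT assay, with a stated time of 3 days; a lower number here means a stronger inhibitor, a higher number a weaker inhibitor:
- compound 1 `COc1ccc(-c2ccccc2)cc1`: 45 ug/mL
- compound 2 `COc1ccc(-c2ccccc2)cc1OC`: 41 ug/mL
- compound 3 `COc1ccc(-c2ccc(O)cc2)cc1OC`: 26 ug/mL

In this assay, the three numbers lie within the scatter of one another, so compound 2, at 41 ug/mL, cannot be separated from the other two compounds. Compound 4 `COc1ccc(-c2cccc(N)c2)cc1OC` is the next case, with this change from compound 2: amino in place of hydrogen on an aromatic carbon. It is an amino in place of hydrogen on an aromatic carbon, meta to a large group.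

For the measured compounds named here, no amino change has been measured, so only two steps bear on it. Methoxy in place of hydrogen gave a 1.1-fold lower number from compound 1 to compound 2 (0.04 log units; within the scatter). Hydroxy in place of hydrogen, the closer of the two as a small group carrying a hydrogen-bond donor, gave a 1.6-fold lower number from compound 2 to compound 3 (0.20 log units; within the scatter). Neither step leaves the scatter, so no step beyond the scatter is expected in this assay, and any drift would most likely be toward a lower number, as with compound 3. The expected change is a 1.3-fold lower number from compound 2 to compound 4 (0.11 log units; within the scatter). For compound 4 the estimated value is 32 ug/mL, with an expected range of 15 ug/mL to 60 ug/mL.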

Compound 4, half-maximal inhibitory concentration: 4 ug/mL
The estimate for compound 4 lay 8.0-fold (0.90 log units) above the measured number; measured number below the stated range.
By their numbers in this assay, from the lowest: compound 4; then compounds 3, 2 and 1 (each within the scatter of the next).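

In this assay, for the compounds shown here, amino in place of hydrogen on an aromatic carbon, meta to a large group, gives a 10-fold lower number from compound 2 to compound 4 (1.01 log units; beyond the scatter) and is the only step that leaves the scatter. The methoxy step, a 1.1-fold lower number from compound 1 to compound 2 (0.04 log units; within the scatter) and the hydroxy step, a 1.6-fold lower number from compound 2 to compound 3 (0.20 log units; within the scatter) and both stay within it, so the shared core can respond strongly to a single substitution, and this amino change is the one shown to do so. Nothing measured here bears on the reason for this large step.

From the compounds shown here alone, whether the step belongs to the amino group itself or to its place on the ring remains open. Also open, going by these compounds, is how an acetamide, a dimethylamino group or an aminomethyl group would read at the same place.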